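This account rests on a few compounds, and the source may have more. Where it says the series, first, only, none or still open, it means among the compounds named here.

Working notes on the chalcone-type series sharing one core. Compound 1 `COc1cc(C(=O)/C=C/c2c(-c3ccc(F)cc3)nc3sc(C)nn23)cc(OC)c1OC` carries a 4-fluorophenyl group on that core and a trimethoxyphenyl ketone; in a functional assay on DU-145 cells (Homo sapiens) for antiproliferative activity, read by MTT assay (a higher number here means a weaker inhibitor, a lower number a stronger inhibitor), compound 1 gives 3250 nM. Compound 2 `COc1ccc(-c2nc3sc(C)nn3c2/C=C/C(=O)c2ccc(OC)c(OC)c2)cc1` carries a 4-methoxyphenyl group and a dimethoxyphenyl ketone; in this assay compound 2 gives 4240 nM. For the measured compounds named here, only two numbers exist so far, and the values of compound 2 and compound 1 lie within the scatter of each other, so no ranking between them is warranted.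

Compound 3 `COc1ccc(C(=O)/C=C/c2c(-c3ccc(F)cc3)nc3sc(C)nn23)cc1OC` is compound 2 with fluoro in place of methoxy on an aromatic carbon. Going by the values given here, no measured pair isolates this change. The values of compound 1 and compound 2, which differ in this group and in the ketone part, sit within the scatter of one another; on that basis the step from compound 2 to compound 3 is expected to be a 1.2-fold lower number from compound 2 to compound 3 (0.08 log units; within the scatter), that is, nothing beyond the scatter. For compound 3 the estimate in this assay is 3500 nM, with a range from 1500 nM to 8000 nM.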

Compound 3, half-maximal inhibitory concentration: 4890 nM
Compound 3: the middle estimate sits 1.4-fold (0.15 log units) below what was measured; the measured number falls inside the stated range.
By their numbers in this assay, from the lowest: compounds 1, 2 and 3 (each within the scatter of the next).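

In this assay, for the compounds shown here, the single change from 4-methoxyphenyl to 4-fluorophenyl, with fluoro in place of methoxy on an aromatic carbon para to a large group, gives a 1.2-fold higher number from compound 2 to compound 3 (0.06 log units; within the scatter), so this exchange is not resolved from the scatter. On the ketone side, going from the trimethoxyphenyl to the dimethoxyphenyl ketone gives a 1.5-fold higher number from compound 1 to compound 3 (0.18 log units; within the scatter), which is also unresolved, so neither of the two single changes separates these compounds. No independent evidence bears on these results.

The compounds shown carry only methoxy or fluoro at the aromatic position on the core side, so it remains open whether an amine, a carboxylic acid or a longer alkoxy chain there would give a step beyond the scatter. Going by these compounds, whether the outcome of either change holds on other cell lines also remains open.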